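A few compounds are considered here, and "the series" means these few. Any claim that something is new, unique, unknown or untested is made for them only; others in the source may bear on it.

Compound 3 `CC(=O)N1CC(CNC(=O)c2ccncc2Nc2cc(-c3ccc4ccn(C)c4c3)c3nccnc3c2)C1` marks the far end of what has been measured: in an assay on lysate for inhibition of 6-phosphofructo-2-kinase/fructose-2,6-bisphosphatase 3 (Homo sapiens), with stated times of 0.5 min and 45 min (on this read-out lower numbers stand for stronger inhibition and higher numbers for weaker inhibition), compound 3 gives > 100000 nM, which is a limit of the assay rather than a number. By comparison compound 1 `Cn1ccc2ccc(-c3cc(Nc4cnccc4C(=O)NC4CCNC(=O)C4)cc4nccnc34)cc21` gives 56500 nM and compound 2 `CC(=O)N1CCCC(NC(=O)c2ccncc2Nc2cc(-c3ccc4ccn(C)c4c3)c3nccnc3c2)C1` gives 13500 nM. Compound 4 `CC(=O)N1CCC(NC(=O)c2ccncc2Nc2cc(-c3ccc4ccn(C)c4c3)c3nccnc3c2)C1` differs from compound 3 by 1-acetylpyrrolidin-3-yl in place of (1-acetylazetidin-3-yl)methyl on an amide-type nitrogen. Among the compounds with values here, two measured steps bear on this: an at least 7.4-fold higher number from compound 2 to compound 3 (0.86 log units; beyond the scatter) and an at least 1.7-fold higher number from compound 1 to compound 3 (0.24 log units; that floor lies within the scatter), though the second floor lies within the scatter. Moving the ring directly onto the amide nitrogen partly undoes the change that gave the first of these, so a lower number is expected. Compound 4 is therefore estimated at 30000 nM, with a range from 8000 nM to 110000 nM. That would mean an expected step of an at least 3.3-fold lower number from compound 3 to compound 4 (0.52 log units; beyond the scatter).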

Compound 4, half-maximal inhibitory concentration: > 100000 nM
Compound 4 was reported as a limit; the forecaster's own chance of this, stated with the estimate: 30%; middle value at least 3.3-fold (0.52 log units) away from the limit.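

Compound 4, like compound 3, is reported only as a limit of the assay, so the step between them cannot be read because neither has a number: the limit of > 100000 nM in this assay, at which 2 of the 4 values shown sit.

With 1-acetylpyrrolidin-3-yl on the amide-type nitrogen, the result is an at least 7.4-fold higher number from compound 2 to compound 4 (0.86 log units; beyond the scatter), and against the 2-oxopiperidin-4-yl group it is an at least 1.7-fold higher number from compound 1 to compound 4 (0.24 log units; that floor lies within the scatter). Of the three acetylated groups shown, only the 1-acetylpiperidin-3-yl of compound 2 gives a measurable number.

On these data alone, it remains open how far beyond the limit compound 3 and compound 4 lie, and whether a free pyrrolidin-3-yl amine on the same nitrogen would give a measurable number.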